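Compound 2 to compound 4: a furan-2-yl exchange

A few compounds are considered here, and "the series" means these few. Any claim that something is new, unique, unknown or untested is made for them only; others in the source may bear on it.

In a functional assay on the whole organism with Mus musculus as the target (a lower number here means that less compound is needed, a higher number that more compound is needed for the effect), compound 1 (`CNC(=O)[C@H](CO)NCc1ccc(OCc2ccccc2)cc1`) gives 15 mg/kg and compound 2 (`C[C@@H](NCc1ccc(OCc2ccccc2Cl)cc1)C(N)=O`) gives 17.4 mg/kg, while compound 3 (`CNC(=O)[C@@H](CO)NCc1ccc(OCc2cccc(C(F)(F)F)c2)cc1`) gives 19.5 mg/kg in the same read-out. Compound 2 stands within the scatter of both other compounds. Compound 4 (`C[C@@H](NCc1ccc(OCc2ccco2)cc1)C(N)=O`) carries furan-2-yl in place of 2-chlorophenyl on a saturated chain carbon bound to an oxygen on an aromatic ring. Among the compounds with values here, no measured pair differs in one place only, so the expectation starts from compound 2 at 17.4 mg/kg and foresees no step beyond the scatter in this assay. The estimated change is a 1.1-fold higher number from compound 2 to compound 4 (0.06 log units; within the scatter), a step expected to stay within the scatter. For compound 4 the estimated value is 20 mg/kg, with an expected range from 10 mg/kg to 40 mg/kg.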

Compound 4, dose for half-maximal effect: 116 mg/kg
The estimate for compound 4 lay 5.8-fold (0.76 log units) below the measured number; measured number outside the range, above it.
By their numbers in this assay, from the lowest: compounds 1, 2 and 3 (each within the scatter of the next); then compound 4.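

In this assay, within the data shown here, furan-2-yl in place of 2-chlorophenyl on a saturated chain carbon bound to an oxygen on an aromatic ring gives a 6.7-fold higher number from compound 2 to compound 4 (0.82 log units; beyond the scatter), the only step so far that can be read. This position therefore does not accept every aromatic ring alike: here, the five-membered ring with one hetero atom requires more compound for the effect than 2-chlorophenyl. No data at hand bear on the cause of this step.

Still open, on these data alone, is whether the step follows from the loss of chlorine, the ring size or the ring oxygen. Unsubstituted phenyl or thiophen-2-yl on the core of compound 2 would separate these.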